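A few compounds are considered here, and "the series" means these few. Any claim that something is new, unique, unknown or untested is made for them only; others in the source may bear on it.

Two compounds measured in an assay on isolated protein for inhibition of Amine oxidase [flavin-containing] B (Homo sapiens) (a lower number here means a stronger inhibitor, a higher number a weaker inhibitor), set the scene. Compound 1 `CCN(CCCCOc1ccc(/C=C/C(=O)c2ccc(N(C)C)cc2O)cc1)Cc1ccccc1N(C)C` gives 4300 nM. Compound 2 `CCN(CCCOc1ccc(C(=O)/C=C/c2ccc(N(C)C)cc2)c(O)c1)Cc1ccccc1OC` gives 10800 nM, the highest of the two numbers, and the gap to compound 1 lies beyond the scatter. Compound 3 `CCN(CCCOc1ccc(C(=O)/C=C/c2ccc(N(C)C)cc2)c(O)c1)Cc1ccccc1` has not yet been measured; it differs from compound 2 in one place: hydrogen in place of methoxy on an aromatic carbon. For the measured compounds named here, nothing among the measured pairs tracks this change, so a step of at most modest size is expected in this assay, not clearly beyond the scatter in either direction. For compound 3 the expected value is 9000 nM, in the range 3000 nM to 27000 nM, an expected step of a 1.2-fold lower number from compound 2 to compound 3 (0.08 log units; within the scatter).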

Compound 3, half-maximal inhibitory concentration: 13100 nM
Compound 3: the middle estimate sits 1.5-fold (0.16 log units) below what was measured; the measured number falls inside the stated range.
By their numbers in this assay, from the lowest: compound 1; then compounds 2 and 3 (each within the scatter of the next).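

Going from 2-methoxybenzyl to benzyl gives a 1.2-fold higher number from compound 2 to compound 3 (0.08 log units; within the scatter) in this assay, so compound 2 and compound 3 cannot be told apart. For the compounds shown here, the methoxy on this aromatic carbon can thus be removed without a change beyond the scatter, something the earlier compounds could not show, as no measured pair tracked this position. No supporting data explain this result.

On these data alone, whether a fluorine, a chlorine or a hydroxyl group on this aromatic carbon would leave the number equally unmoved stays open. So does whether the same change behaves alike with a longer chain.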